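Ethyl in Place of Hydrogen on the Imine-Bound Carbon

A few compounds are considered here, and "the series" means these few. Any claim that something is new, unique, unknown or untested is made for them only; others in the source may bear on it.

This account follows a single change in a small series of acylguanidine-like compounds tested in a functional assay (aorta) for inhibition, with Rattus norvegicus as the target; a higher number here means a weaker inhibitor, a lower number a stronger inhibitor. Compound 1 `CCC(C)(C)/N=C(\NC#N)Nc1ccc(I)cc1` gives 1.4 nM, the lowest number of the two full values available. Compound 2 `CC(C)/N=C(\NC#N)Nc1ccc(C#N)cc1` stands at the other end: in this assay compound 2 gives 19000 nM, the highest of the two numbers and a gap beyond the scatter from compound 1, although the two differ in more than one place, so the two values show only that difference and nothing about which part of the structure carries it. Compound 3 `CCC(C)(C)/N=C(\NC#N)Nc1ccc(S(=O)(=O)N2CCCCC2)cc1` gives > 30 nM, which is a limit of this assay and not a number; it sits at the limit of > 30 nM in this assay, at which 1 of the 3 values shown sits.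

The unmeasured compound 4 `CCC(C)(C)/N=C(\NC#N)Nc1ccc(C#N)cc1` departs from compound 2 in one place: ethyl in place of hydrogen on a saturated chain carbon bound to a double-bonded nitrogen and two saturated chain carbons. With this change compound 4 shares the saturated chain of compound 1 while keeping the aromatic substitution of compound 2.

Compound 4 is expected to be a markedly stronger inhibitor than compound 2, with a step of a 190-fold lower number from compound 2 to compound 4 (2.28 log units; beyond the scatter) in this assay, well beyond the scatter. The estimate for compound 4 in this assay is 100 nM, with a range from 10 nM to 2000 nM.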

Compound 4, half-maximal inhibitory concentration: 130 nM
The estimate for compound 4 lay 1.3-fold (0.11 log units) below the measured number; the measured number falls inside the stated range.
By their numbers in this assay, from the lowest: compound 1; then compound 4; then compound 2.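

With the nitrile on the aromatic carbon held fixed, the change from isopropyl to 1,1-dimethylpropyl can now be read on its own in this assay, where the step is a 150-fold lower number from compound 2 to compound 4 (2.16 log units; beyond the scatter) and shows that this saturated chain carbon is a place where a small addition of ethyl in place of hydrogen goes with a large gain in strength. For the compounds shown here, compound 4 also gives a second single change with the 1,1-dimethylpropyl chain held constant, cyano in place of iodo on an aromatic carbon, with the step of a 93-fold higher number from compound 1 to compound 4 (1.97 log units; beyond the scatter) and so shows that the aromatic substituent matters as well, which the earlier compounds, differing in more than one place, could not separate. Nothing measured here accounts for either step.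

For compound 3 the entry > 30 nM is a limit and not a number, so its place in the order cannot be read. Going by these compounds, whether a longer chain such as hexyl on the saturated carbon, or a carboxylic acid in place of the nitrile on the aromatic carbon, would extend these trends remains open, as does whether the ethyl step would be as large with iodo on the aromatic carbon.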